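The source may hold more compounds than are shown below. What is called first, only, known or untested is meant among the compounds shown, and "the series" means these compounds.

Working notes on the series.

Compound 1 `COc1ccc(C2=NN(C(=O)c3ccc(Cl)nc3)C(c3ccc(OCc4ccccc4)cc3)C2)cc1` carries a 6-chloropyridin-3-yl on the carbonyl carbon whose other neighbour is an amide-type nitrogen in a ring. In a functional assay on WM 266-4 cells (Homo sapiens) for antiproliferative activity, read by MTT assay, with a stated time of 24 h (on this read-out higher numbers stand for weaker inhibition of growth and lower numbers for stronger inhibition of growth), compound 1 gives 10600 nM. Compound 2 `COc1ccc(C2=NN(C(=O)c3ccc(C)nc3Cl)C(c3ccc(OCc4ccccc4)cc3)C2)cc1` is the single-point variant with 2-chloro-6-methylpyridin-3-yl in place of 6-chloropyridin-3-yl on a carbonyl carbon. In this assay compound 2 gives 10500 nM, so a 1.0-fold lower number from compound 1 to compound 2 (0.00 log units; within the scatter).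

Compound 3 `O=C(c1ccc(Cl)nc1)N1N=C(c2ccc(Cl)cc2)CC1c1ccc(Cl)cc1` is built on a different core; the difference between the two cores is not broken down here. In this assay compound 3 gives 9890 nM. All three numbers sit within the scatter of one another, so no order among compounds 1, 2 and 3 can be read from these data.

Compound 4 `Cc1ccc(C(=O)N2N=C(c3ccc(Cl)cc3)CC2c2ccc(Cl)cc2)c(Cl)n1` has not yet been measured in this assay. It differs from compound 3 by 2-chloro-6-methylpyridin-3-yl in place of 6-chloropyridin-3-yl on a carbonyl carbon, the same change that separates compound 2 from compound 1, at the same place. The expectation is that a 1.0-fold higher number from compound 3 to compound 4 (0.00 log units; within the scatter), because a 1.0-fold lower number from compound 1 to compound 2 (0.00 log units; within the scatter) stayed within the scatter. Compound 4 is therefore estimated at 9900 nM in this assay, expected between 5000 nM and 20000 nM.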

Compound 4, concentration for 50% growth inhibition: 8870 nM
Beside the measured number, compound 4's estimate is 1.1-fold (0.05 log units) above it, within the range that was stated.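

Putting 2-chloro-6-methylpyridin-3-yl in place of 6-chloropyridin-3-yl on the carbonyl carbon gives, on the core of compound 3 in this assay, a 1.1-fold lower number from compound 3 to compound 4 (0.05 log units; within the scatter). The change therefore reads the same on both cores, with no difference between the two steps that exceeds the scatter: the same change on two cores in this assay, a 1.0-fold lower number (0.00 log units; within the scatter) from compound 1 to compound 2 and a 1.1-fold lower number (0.05 log units; within the scatter) from compound 3 to compound 4, 1.1-fold (0.04 log units) apart, within the scatter of two such steps. Within the data shown here, this shows that the change left the read-out within the scatter on these two cores, but with only two pairs in one assay it does not show that the same would hold on other cores or in other assays.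

The compounds shown leave open whether a more different group on the carbonyl carbon would move the number, such as a pyridine ring bearing an amine or a carboxylic acid in place of the chlorine, or a longer chain in place of the methyl. They also leave open what each part of the core contributes, as compounds 1 and 3 differ in more than one place.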